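Shortening an ethyl to a methyl on a piperazine ring

A few compounds are considered here, and "the series" means these few. Any claim that something is new, unique, unknown or untested is made for them only; others in the source may bear on it.

Compound 1, `Cc1cn2nc(-c3cc(=O)n4cc(N5CCN(C)CC5)ccc4n3)cc2cn1`: < 10 ng.h/mL
Compound 2, `Cc1cn2cc(-c3cc4ccc(N5CCN(C)CC5)cc4oc3=O)nc2cn1`: < 10 ng.h/mL
Compound 3, `CCN1CCN(c2ccc3cc(-c4cn5cc(C)nc(C)c5n4)c(=O)oc3c2)C[C@@H]1C`: 1100 ng.h/mL

In an ADME assay on the whole organism (Rattus norvegicus, strain Sprague-Dawley) for pharmacokinetics, with a stated time of 6 h, at a dose of 10 mg/kg by the oral route (a higher number here means more compound in the circulation at the dose given, a lower number less compound in the circulation), compound 1 gives only a limit of the assay, < 10 ng.h/mL. Compound 2 likewise gives only a limit, < 10 ng.h/mL. For the measured compounds named here, compound 3 is the one compound with a true number in this assay, at 1100 ng.h/mL; the other two values sit at the limit of < 10 ng.h/mL in this assay, at which 2 of the 3 values shown sit. Compound 4, `Cc1cn2cc(-c3cc4ccc(N5CCN(C)[C@@H](C)C5)cc4oc3=O)nc2c(C)n1`, has not yet been measured. It differs from compound 3 by hydrogen in place of methyl on a saturated chain carbon bound to an amine nitrogen in a ring. Going by the values given here, no measured pair shows this change, so the expected step in this assay is small and within the usual scatter, leaning slightly downward: a 1.8-fold lower number from compound 3 to compound 4 (0.26 log units; within the scatter). Compound 4 is therefore estimated at 600 ng.h/mL, with a likely range from 150 ng.h/mL to 2000 ng.h/mL.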

Compound 4, area under the concentration-time curve: 260 ng.h/mL
The estimate for compound 4 lay 2.3-fold (0.36 log units) above the measured number, and the stated range covers the measured number.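

Shortening ethyl to methyl, from 4-ethyl-3-methylpiperazin-1-yl to 3,4-dimethylpiperazin-1-yl, is the first change in one place that can be read here, and it gives a 4.2-fold lower number from compound 3 to compound 4 (0.63 log units; beyond the scatter) in this assay. This small edit on the piperazine ring is therefore enough to move the number beyond the usual scatter. No measurement shown explains the step.

From the compounds shown here alone, whether a longer chain such as propyl, or a plain hydrogen on that amine nitrogen, would raise or lower the number remains open. One pair also cannot show whether the same change acts alike on other cores.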